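The compounds below may be only part of what the source reports. "The series", "measured", "known", "first", "only" and "open" are said of these compounds alone.

Measured so far in an ADME assay (liver) for metabolic stability, with Liver microsome (Homo sapiens) as the target, read by LC-MS, using microsomes and NADPH, with a stated time of 5 min, at 37 degrees C; a lower number here means slower removal, a higher number faster removal of the compound:
- compound 1 `CCn1c([C@@H](C)NS(=O)(=O)c2ccccc2)nc2ccc(C(F)(F)F)cc21` gives 14 mL.min-1.g-1 
- compound 2 `CCn1c([C@@H](C)NS(=O)(=O)c2cn(C)nc2C)nc2ccc(C(F)(F)F)cc21` gives 28 mL.min-1.g-1 

On these numbers, compound 2 stands within the scatter of compound 1. Compound 3 `CCn1ncc(S(=O)(=O)N[C@H](C)c2nc3ccc(C(F)(F)F)cc3n2CC)c1C` brings 1-ethyl-5-methyl-1H-pyrazol-4-yl in place of 1,3-dimethyl-1H-pyrazol-4-yl on a sulfonyl sulfur on a sulfonyl sulfur. For the measured compounds named here, the only measured step at this place is a 2.0-fold higher number from compound 1 to compound 2 (0.30 log units; within the scatter) and it lies within the scatter. Going by the values given here, no measured step exchanges one pyrazolyl group for another. No step beyond the scatter is therefore expected in this assay and the estimated change is a 1.1-fold higher number from compound 2 to compound 3 (0.06 log units; within the scatter) at most a small one. For compound 3 the estimate is 32 mL.min-1.g-1 with an expected range from 14 mL.min-1.g-1 to 70 mL.min-1.g-1 in this assay.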

Compound 3, intrinsic clearance in microsomes: > 100 mL.min-1.g-1
Compound 3: no number, only a limit (the forecaster's own chance of this, stated with the estimate: 3%); at least 3.1-fold (0.49 log units) between middle value and limit.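

In this assay the reading for compound 3 is a limit and not a number: the limit of > 100 mL.min-1.g-1 in this assay, at which 1 of the 3 values shown sits. Even so, the place on the sulfonyl sulfur proves sensitive to an exchange of one pyrazolyl group for another, with an at least 3.5-fold higher number from compound 2 to compound 3 (0.55 log units; beyond the scatter). Against phenyl, 1-ethyl-5-methyl-1H-pyrazol-4-yl gives an at least 7.1-fold higher number from compound 1 to compound 3 (0.85 log units; beyond the scatter), whereas the earlier step to 1,3-dimethyl-1H-pyrazol-4-yl stayed within the scatter.

Still open, going by these compounds, are the true size of these steps and whether the ethyl group or the placement of the methyl group carries them. A 1,5-dimethyl-1H-pyrazol-4-yl group would separate the two.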